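The source may report more compounds than this note shows. Statements on the series, on what has been measured and on what is new or still open speak of the compounds shown alone.

Within the data shown here, in a functional assay on HT-29 cells (Homo sapiens) for antiproliferative activity, read by MTT assay, with a stated time of 72 h (on this read-out lower numbers stand for stronger inhibition and higher numbers for weaker inhibition), three compounds that share one core and differ only in the group on an amine nitrogen in a ring have numbers so far. Compound 1 (`Nc1nc(N)c2cc(CSC(=S)N3CCN(C4CCCCC4)CC3)ccc2n1`), with cyclohexyl at that spot, gives 4050 nM. Compound 2 (`Cc1ccccc1N1CCN(C(=S)SCc2ccc3nc(N)nc(N)c3c2)CC1`), with 2-methylphenyl, gives 2950 nM. Compound 3 (`Nc1nc(N)c2cc(CSC(=S)N3CCN(c4ccc(Cl)cc4)CC3)ccc2n1`), with 4-chlorophenyl, gives 7480 nM. Only one gap among these exceeds the scatter, and it is modest: a 2.5-fold higher number from compound 2 to compound 3 (0.40 log units; beyond the scatter). The other two, a 1.8-fold higher number from compound 1 to compound 3 (0.27 log units; within the scatter) and a 1.4-fold lower number from compound 1 to compound 2 (0.14 log units; within the scatter), lie within it, so compound 3 stands apart from only one of the other two.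

Compound 4 (`Nc1nc(N)c2cc(CSC(=S)N3CCN(c4ccc(Cl)c(Cl)c4)CC3)ccc2n1`) keeps everything in compound 3 but adds a second chlorine, turning 4-chlorophenyl into 3,4-dichlorophenyl: chloro in place of hydrogen on an aromatic carbon. Among the measured compounds shown here, no measured pair shows this exact change. The nearest evidence is the swaps of the whole group on the same nitrogen, and even the largest of these, a 2.5-fold higher number from compound 2 to compound 3 (0.40 log units; beyond the scatter), is modest. Adding one chloro is a smaller edit than those swaps, and the data give no direction for it, so no step beyond the scatter is expected. The expected step, a 1.2-fold lower number from compound 3 to compound 4 (0.10 log units; within the scatter), is an estimate that stays within the scatter. For compound 4 the estimate is 6000 nM, with an expected range from 2600 nM to 13000 nM.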

Compound 4, half-maximal inhibitory concentration: 3480 nM
For compound 4 the middle estimate is 1.7-fold (0.24 log units) above the measured one, within the range that was stated.
By their numbers in this assay, from the lowest: compounds 2, 4, 1 and 3 (each within the scatter of the next, the first and the last beyond it).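

In this assay, among these compounds, placing a chloro on the aromatic carbon ortho to the existing chloro group and meta to a large group gives a real, though modest, change (a 2.1-fold lower number from compound 3 to compound 4 (0.33 log units; beyond the scatter)), so this ring position, which carries hydrogen in compound 3, does affect the read-out, and a single added atom can produce a step beyond the scatter, something the earlier compounds showed only for a swap of the whole group. The new 3,4-dichlorophenyl compound cannot be separated from either the 2-methylphenyl or the cyclohexyl compound, with a 1.2-fold higher number from compound 2 to compound 4 (0.07 log units; within the scatter) and a 1.2-fold lower number from compound 1 to compound 4 (0.07 log units; within the scatter) both within the scatter, so adding the second chlorine removes the one clear gap that set the 4-chlorophenyl group of compound 3 apart from compound 2. No measurement shown here accounts for this step.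

The compounds shown leave open whether the change depends on chlorine itself or would also appear with a fluoro, methyl or methoxy group on the same carbon. They also leave open whether a chloro at that carbon has the same effect in a 3-chlorophenyl group, without the chloro already present in compound 3.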